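The source may hold more compounds than are shown below. What is called first, only, known or untested is meant among the compounds shown, and "the series" means these compounds.

Compound 3 `OC[C@H]1C[C@@H](Cn2cnc3c(Cl)ncnc32)c2ccccc21` gives 24 ug/mL in a functional assay on CCRF-CEM cells (Homo sapiens); on this read-out higher numbers stand for weaker inhibition and lower numbers for stronger inhibition. On the numbers at hand it stands level with compound 2 `COc1ncnc2c1ncn2C[C@@H]1C[C@H](CO)c2ccccc21`, which gives 24 ug/mL; the step of no change at the digits printed from compound 2 to compound 3 (within the scatter), and together the two hold the highest numbers of the three. Compound 1 `OC[C@H]1C[C@@H](Cn2cnc3c(-c4ccc(Cl)cc4)ncnc32)c2ccccc21` gives 0.63 ug/mL; the steps of a 38-fold higher number from compound 1 to compound 2 (1.58 log units; beyond the scatter) and a 38-fold higher number from compound 1 to compound 3 (1.58 log units; beyond the scatter) are both large.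

Compound 4 `CCCNc1ncnc2c1ncn2C[C@@H]1C[C@H](CO)c2ccccc21` differs from compound 3 in one place: propylamino in place of chloro on an aromatic carbon. Within the data shown here, no measured step exchanges chloro for propylamino. Among the measured compounds shown here, the only step at the same position that keeps a small group in place is no change at the digits printed from compound 2 to compound 3 (within the scatter), which stayed within the scatter, while the large steps seen here all involved the loss of the 4-chlorophenyl group. The expectation for compound 4 is therefore a step of a 1.6-fold lower number from compound 3 to compound 4 (0.20 log units; within the scatter) that stays near the scatter. Compound 4 is expected to give about 15 ug/mL, with a range from 4 ug/mL to 50 ug/mL.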

Compound 4, half-maximal inhibitory concentration: 24 ug/mL
Estimate against measurement, compound 4: 1.6-fold (0.20 log units) below; the measured number falls inside the stated range.
By their numbers in this assay, from the lowest: compound 1; then compounds 2, 3 and 4 (each within the scatter of the next).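

Propylamino brings more heavy atoms than chloro and a hydrogen-bond donor, yet in this assay the reading shows no change at the digits printed from compound 3 to compound 4 (within the scatter) and likewise no change at the digits printed from compound 2 to compound 4 (within the scatter), so an amine on this aromatic carbon reads the same as chloro or methoxy. Only 4-chlorophenyl stands apart, as a 38-fold higher number from compound 1 to compound 4 (1.58 log units; beyond the scatter) shows for the third time, and among these four compounds it is the only group at this place that carries a ring. No evidence at hand explains this difference.

The compounds shown leave open whether the chlorine of that group matters, which a plain phenyl would test. They also leave open whether a benzylamino group, which carries a ring on an amine nitrogen, would follow 4-chlorophenyl or propylamino.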